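Compound 3 to compound 4: a step against a limit

The source may report more compounds than this note shows. Statements on the series, on what has been measured and on what is new or still open speak of the compounds shown alone.

Compound 1 `O=C1OC(Cc2nc(-c3ccc(Oc4ccccc4)cc3)no2)c2ccccc21`: > 40000 nM, a limit
Compound 2 `CCCOc1ccc(C(O)C2OC(=O)c3c(OC)cc(OC)cc32)cc1`: > 40000 nM, a limit
Compound 3 `CCC(C)Oc1ccc(C(O)C2OC(=O)c3c(OC)cc(OC)cc32)cc1`: > 40000 nM, a limit

All three entries come from an ADME assay on RAW264.7 cells (Mus musculus) for cytotoxicity, read by MTT assay, with a stated time of 24 h, in the absence of a further agent (a lower number here means a stronger inhibitor, a higher number a weaker inhibitor), and none of them is an exact number. Compound 3 stands at the limit of > 40000 nM in this assay, at which 3 of the 3 values shown sit. So far, then, the measurements show no inhibition strong enough to be given a number, and they offer no ranking among these compounds.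

The next compound is compound 4 `COc1cc(OC)c2c(c1)C(C(O)c1ccc(OCCOc3ccccc3)cc1)OC2=O`. It carries 2-phenoxyethyl in place of sec-butyl on an oxygen on an aromatic ring. The same change can be read as sec-butoxy to 2-phenoxyethoxy. The group that enters is clearly the larger of the two and brings a ring of its own.

Within the data shown here, only one measured step bears on this change, and it is a step that the two limits leave unreadable from compound 2 to compound 3. It alters the same chain on the oxygen but gives no size to carry over. With no readable step to draw on, no step beyond the usual scatter is expected in this assay, in either direction, and compound 4 will most likely be reported as a limit again. The expected step is a step that the limit leaves unreadable from compound 3 to compound 4. For compound 4 the estimated value is 45000 nM, with an expected range from 15000 nM to 100000 nM.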

Compound 4, half-maximal inhibitory concentration: > 40000 nM
Compound 4: only a limit was reported (the forecaster's own chance of this, stated with the estimate: 70%); the middle value does not contradict the limit.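

In this assay compound 4 gives > 40000 nM, which is a limit and not an exact number. Among these compounds, compound 2 and compound 3 are also recorded as limits, so no step to compound 4 can be read. The compounds shown leave open how strongly any of them inhibits these cells, and whether changing the group on this oxygen matters at all: the limit of > 40000 nM in this assay, at which 4 of the 4 values shown sit.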